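The source may hold more compounds than are shown below. What is called first, only, known or untested is meant among the compounds shown, and "the series" means these compounds.

Compound 1, `CCCC(=O)OCC1CN(C(=O)c2cc(OC)c(OC)c(OC)c2)CCN1C(=O)c1cc(OC)c(OC)c(OC)c1`: 420 nM
Compound 2, `CCCCCCCCCC(=O)OCC1CN(C(=O)c2cc(OC)c(OC)c(OC)c2)CCN1C(=O)c1cc(OC)c(OC)c(OC)c1`: 2820 nM
Compound 3, `COc1cc(C(=O)N2CCN(C(=O)c3cc(OC)c(OC)c(OC)c3)C(COC(=O)CC(C)(C)C)C2)cc(OC)c1OC`: 120 nM

In a functional assay (Oryctolagus cuniculus) for inhibition of platelet-activating factor receptor (Cavia porcellus) (on this read-out lower numbers stand for stronger inhibition and higher numbers for weaker inhibition), compound 3 gives the lowest of the three numbers. Its nearest neighbour is compound 1, with a 3.5-fold lower number from compound 1 to compound 3 (0.54 log units; beyond the scatter); the furthest is compound 2, with a 24-fold lower number from compound 2 to compound 3 (1.37 log units; beyond the scatter). Compound 4, `COc1cc(C(=O)N2CCN(C(=O)c3cc(OC)c(OC)c(OC)c3)C(COC(=O)NC(C)C(C)(C)C)C2)cc(OC)c1OC`, has not yet been measured. It differs from compound 3 in that ((1,2,2-trimethylpropyl)amino in place of neopentyl on a carbonyl carbon). The branched tert-butyl end of the chain is kept, while an amino group with one hydrogen-bond donor enters between it and the carbonyl carbon. The measured steps only speak to the chain itself: a 3.5-fold lower number from compound 1 to compound 3 (0.54 log units; beyond the scatter) shows branching near the carbonyl carbon lowering the number, and a 6.7-fold higher number from compound 1 to compound 2 (0.83 log units; beyond the scatter) shows a longer chain raising it. Among the compounds with values here, no measured pair changes the atom bound to the carbonyl carbon, so that part of the change is untested. Compound 4 is therefore expected to stay close to compound 3, with a 1.7-fold higher number from compound 3 to compound 4 (0.22 log units; within the scatter), a step not clearly beyond the scatter in either direction. The estimate for compound 4 in this assay is 200 nM, within a range of 60 nM to 700 nM.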

Compound 4, half-maximal inhibitory concentration: 170 nM
Compound 4: middle estimate off by 1.2-fold (0.07 log units), on the high side; measured number inside the range.
By their numbers in this assay, from the lowest: compounds 3 and 4 (each within the scatter of the next); then compound 1; then compound 2.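

In this assay, within the data shown here, the first change to the atom bound to the carbonyl carbon, (1,2,2-trimethylpropyl)amino in place of neopentyl, gives a 1.4-fold higher number from compound 3 to compound 4 (0.15 log units; within the scatter), so a chain carrying one hydrogen-bond donor at this place reads the same as the all-carbon chain within the scatter. The branched amino chain also keeps the standing of the neopentyl ester over the straight chains, with a 2.5-fold lower number from compound 1 to compound 4 (0.39 log units; beyond the scatter) and a 17-fold lower number from compound 2 to compound 4 (1.22 log units; beyond the scatter). Nothing in the available evidence accounts for this result.

Compound 4 adds the nitrogen and extra carbons in a single step, so the compounds shown leave open what the nitrogen does alone, as a neopentylamino group on the same carbonyl carbon would show. They also leave open whether a straight propylamino or nonylamino chain would follow the same order as the esters of compound 1 and compound 2.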